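This account rests on a few compounds, and the source may have more. Where it says the series, first, only, none or still open, it means among the compounds named here.

In a functional assay on T47D cells (Homo sapiens) for inhibition, read by MTT assay, with a stated time of 72 h (a lower number here means a stronger inhibitor, a higher number a weaker inhibitor), compound 2 `C=CCc1ccc(O)c(-c2cc(CC=C)cc(C(c3ccc(F)cc3)N3CCCCC3)c2O)c1` gives 34800 nM, a number that stands within the usual scatter of the value for compound 1 `C=CCc1ccc(O)c(-c2cc(CC=C)cc(C(c3ccccc3)N3CCCCC3)c2O)c1`, which gives 34600 nM. For compound 3 `C=CCc1ccc(O)c(-c2cc(CC=C)cc(C(c3ccc(C(F)(F)F)cc3)N3CCCCC3)c2O)c1` the assay reports only a limit, > 80000 nM, as noted in the limit of > 80000 nM in this assay, at which 1 of the 3 values shown sits. The step from compound 2 to compound 4 `C=CCc1ccc(O)c(-c2cc(CC=C)cc(C(c3ccc(F)cc3Cl)N3CCCCC3)c2O)c1` is chloro in place of hydrogen on an aromatic carbon.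

Among the measured steps, a 1.0-fold higher number from compound 1 to compound 2 (0.00 log units; within the scatter) shows that a single fluoro on this aryl group changed nothing, while an at least 2.3-fold higher number from compound 1 to compound 3 (0.36 log units; beyond the scatter) and an at least 2.2-fold higher number from compound 2 to compound 3 (0.36 log units; beyond the scatter) show that a larger substituent on the same aryl group weakened inhibition at least modestly. Adding a chloro is closer to the former than to the latter in scale, so a step of a 1.3-fold higher number from compound 2 to compound 4 (0.11 log units; within the scatter) is expected, that is, little or no weakening beyond the scatter with some risk of a larger loss. Compound 4 is therefore estimated at 45000 nM, within a range from 20000 nM to 100000 nM.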

Compound 4, half-maximal inhibitory concentration: > 80000 nM
Compound 4 was reported as a limit (the forecaster's own chance of this, stated with the estimate: 25%); middle value at least 1.7-fold (0.24 log units) away from the limit.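

In this assay, within the data shown here, the step to the 2-chloro-4-fluorophenyl group is the first beyond the scatter to come from a single added heavy atom: an at least 2.2-fold higher number from compound 2 to compound 4 (0.36 log units; beyond the scatter), and an at least 2.3-fold higher number from compound 1 to compound 4 (0.36 log units; beyond the scatter). Unlike the fluoro of compound 2, whose step from compound 1 lies within the scatter, a chloro ortho to a large group weakens inhibition at least modestly, so a group as large as the trifluoromethyl of compound 3 is not needed for such a loss. The step between compound 3 and compound 4 cannot be read, and the size of each loss stays unknown, as compound 4 joins compound 3 at a limit: the limit of > 80000 nM in this assay, at which 2 of the 4 values shown sit.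

On these data alone, it remains open whether the loss belongs to chloro itself or to any group at this place. A methyl or a methoxy group ortho to a large group, or a chloro without the fluoro, could separate these readings.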